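Restoring the amine hydrogen with a dimethylphenyl ring

The compounds below may be only part of what the source reports. "The series", "measured", "known", "first", "only" and "open" are said of these compounds alone.

Compound 1 `FC(F)(F)c1ccc(Nc2ncnc3sc(Nc4c(Cl)cccc4Cl)nc23)cc1`: 12 nM
Compound 2 `CN(c1nc2c(Nc3ccc(C(F)(F)F)cc3)ncnc2s1)c1c(Cl)cccc1Cl`: 502 nM

Compound 2 holds the higher of the two numbers in a functional assay on HEK293 cells for antagonist activity at transient receptor potential cation channel subfamily V member 1 (Homo sapiens), read by calcium flux; on this read-out lower numbers stand for stronger inhibition and higher numbers for weaker inhibition; its nearest neighbour is compound 1, separated by a 42-fold higher number from compound 1 to compound 2 (1.62 log units; beyond the scatter). Compound 3 `Cc1cccc(C)c1Nc1nc2c(Nc3ccc(C(F)(F)F)cc3)ncnc2s1` carries (2,6-dimethylphenyl)amino in place of (2,6-dichlorophenyl)(methyl)amino on an aromatic carbon. Within the data shown here, the one measured step that bears on this is a 42-fold higher number from compound 1 to compound 2 (1.62 log units; beyond the scatter), showing how much was lost when the methyl was added to the nitrogen. Among the measured compounds shown here, compound 3 removes that methyl again but also swaps the (2,6-dichlorophenyl) part for (2,6-dimethylphenyl), a change no measured pair covers. The expected step is a 20-fold lower number from compound 2 to compound 3 (1.30 log units; beyond the scatter), back toward compound 1. Compound 3 is estimated at 25 nM, between 6 nM and 120 nM.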

Compound 3, half-maximal inhibitory concentration: 23 nM
For compound 3 the middle estimate is 1.1-fold (0.04 log units) above the measured one; low and high end bracket the measured number.
By their numbers in this assay, from the lowest: compounds 1 and 3 (each within the scatter of the next); then compound 2.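

In this assay, the step of a 22-fold lower number from compound 2 to compound 3 (1.34 log units; beyond the scatter) shows that a compound with hydrogen on this nitrogen can reach the low range even with a different aromatic ring. The step of a 1.9-fold higher number from compound 1 to compound 3 (0.28 log units; within the scatter) means that 2,6-dimethylphenyl and 2,6-dichlorophenyl on that nitrogen cannot be told apart here. The compounds shown leave open whether a plain phenyl or a pyridine ring would do as well, and how much a methyl on the nitrogen would cost with 2,6-dimethylphenyl. No available evidence explains these results.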